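Triazole amide series: aryl swap at the triazole nitrogen

The compounds below may be only part of what the source reports. "The series", "measured", "known", "first", "only" and "open" are said of these compounds alone.

Measured compounds:
- compound 1 `COc1cc2c(Oc3ccc(NC(=O)c4cn(-c5c(C)cccc5C)nn4)cc3F)ccnc2cc1OCCCN1CCCC1`, 1240 nM
- compound 2 `COc1cc2c(Oc3ccc(NC(=O)c4cn(-c5c(C)cccc5C)nn4)cc3F)ccnc2cc1OCCCN1CCCCC1`, "not determined" (no result reported)
- compound 3 `COc1cc2c(Oc3ccc(NC(=O)c4cn(-c5ccccc5F)nn4)cc3F)ccnc2cc1OCCCN1CCC(C)CC1`, 250 nM

In a functional assay on A549 cells (Homo sapiens) for cytotoxicity, read by MTT assay, with a stated time of 72 h (a lower number here means a stronger inhibitor, a higher number a weaker inhibitor), compound 3 gives 250 nM, the lowest of the two numbers; compound 1 gives 1240 nM, a gap beyond the scatter. Compound 2 has no result in this assay. Compound 1 and compound 3 differ in more than one place, so no single change can be read from their values.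

Compound 4 `COc1cc2c(Oc3ccc(NC(=O)c4cn(-c5c(C)cccc5C)nn4)cc3F)ccnc2cc1OCCCN1CCC(C)CC1` differs from compound 3 by 2,6-dimethylphenyl in place of 2-fluorophenyl on an aromatic nitrogen. Compound 1 carries the same 2,6-dimethylphenyl and sits well above compound 3, but its other difference leaves the effect of the aryl swap alone unknown. For the measured compounds named here, the expectation for this assay is a step upward from compound 3 to compound 4 of a 2.4-fold higher number from compound 3 to compound 4 (0.38 log units; beyond the scatter), with wide uncertainty, since no pair in the set isolates this change.

Compound 4 is therefore estimated at 600 nM in this assay, within a range of 200 nM to 1800 nM.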

Compound 4, half-maximal inhibitory concentration: 3340 nM
For compound 4 the middle estimate is 5.6-fold (0.75 log units) below the measured one; the measured number lies above the stated range.
By their numbers in this assay, from the lowest: compound 3; then compound 1; then compound 4.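

In this assay, the aromatic nitrogen now has a pair that isolates the aryl swap: 2,6-dimethylphenyl in place of 2-fluorophenyl gives a 13-fold higher number from compound 3 to compound 4 (1.13 log units; beyond the scatter), so the aryl group at this position strongly affects the read-out when the rest of the molecule is held constant. At the end of the chain, with 2,6-dimethylphenyl held constant, 4-methylpiperidin-1-yl in place of pyrrolidin-1-yl gives a 2.7-fold higher number from compound 1 to compound 4 (0.43 log units; beyond the scatter), a modest step that is smaller than the aryl step. No measured data bearing on the reason for either step are available.

From the compounds shown here alone, whether the aryl step carries over to compounds with pyrrolidin-1-yl at the chain end remains open. Also open, going by these compounds, is how an unsubstituted phenyl on the aromatic nitrogen, or a morpholine at the chain end, would compare in this assay.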